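A few compounds are considered here, and "the series" means these few. Any claim that something is new, unique, unknown or untested is made for them only; others in the source may bear on it.

Three compounds of one series were tested in an assay on isolated protein for inhibition of Dihydrofolate reductase (Homo sapiens), read by spectrophotometry; a higher number here means a weaker inhibitor, a lower number a stronger inhibitor. Compound 1, `CCN(Cc1nc2cc(C(F)(F)F)ccc2nc1-c1ccccc1)c1ccc(F)cc1`, gives 3000 nM. Compound 2, `CCN(Cc1nc2cc(C(F)(F)F)ccc2nc1-c1ccccc1)c1ccc(OC)cc1`, gives 7000 nM, and compound 3, `C#CCN(Cc1nc2cc(C(F)(F)F)ccc2nc1-c1ccccc1)c1ccc(F)cc1`, gives 8000 nM. Compound 2 arises from compound 1 by methoxy in place of fluoro on an aromatic carbon, and that step reads a 2.3-fold higher number from compound 1 to compound 2 (0.37 log units; beyond the scatter). Compound 3 arises from compound 1 by ethynyl in place of methyl on a saturated chain carbon bound to a nitrogen on an aromatic ring, and that step reads a 2.7-fold higher number from compound 1 to compound 3 (0.43 log units; beyond the scatter). Compound 4, `C#CCN(Cc1nc2cc(C(F)(F)F)ccc2nc1-c1ccccc1)c1ccc(OC)cc1`, has not yet been measured in this assay; it arises from compound 3 by methoxy in place of fluoro on an aromatic carbon, the same change as from compound 1 to compound 2, and the cores of compound 3 and compound 1 differ only by ethynyl in place of methyl on a saturated chain carbon bound to a nitrogen on an aromatic ring. The step from compound 3 to compound 4 is expected to be a 2.3-fold higher number from compound 3 to compound 4 (0.35 log units; beyond the scatter), resting on the step of a 2.3-fold higher number from compound 1 to compound 2 (0.37 log units; beyond the scatter) in the core of compound 1. Compound 4 is therefore estimated at 18000 nM, with a plausible range from 8000 nM to 40000 nM.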

Compound 4, inhibition constant: 3000 nM
For compound 4 the middle estimate is 6.0-fold (0.78 log units) above the measured one; measured number outside the range, below it.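

In this assay, the change from 4-fluorophenyl to 4-methoxyphenyl does not carry over from the core of compound 1 to the core of compound 3, where it reads a 2.7-fold lower number from compound 3 to compound 4 (0.43 log units; beyond the scatter) and so runs the opposite way to the earlier step: the same change on two cores in this assay, a 2.3-fold higher number (0.37 log units; beyond the scatter) from compound 1 to compound 2 and a 2.7-fold lower number (0.43 log units; beyond the scatter) from compound 3 to compound 4, 6.2-fold (0.79 log units) apart, beyond the scatter of two such steps. Ethynyl in place of methyl behaves likewise, reading a 2.3-fold lower number from compound 2 to compound 4 (0.37 log units; beyond the scatter) on the methoxy-bearing core, which also reverses its earlier direction: the same change on two cores in this assay, a 2.7-fold higher number (0.43 log units; beyond the scatter) from compound 1 to compound 3 and a 2.3-fold lower number (0.37 log units; beyond the scatter) from compound 2 to compound 4, 6.2-fold (0.79 log units) apart, beyond the scatter of two such steps. These two comparisons rest on the same four values, so they show a single departure from additivity in this set, and they do not show why it arises or how far it extends through the series.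

Whether the reversal is particular to methoxy and ethynyl remains open, since the compounds shown hold only these two pairs of groups. A chloro or hydroxyl group in place of the methoxy, or a longer chain in place of the ethynyl, could test how widely either change transfers between cores.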